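The compounds below may be only part of what the source reports. "The series", "measured", "known", "first", "only" and "open" are said of these compounds alone.

In a functional assay on PC-3 cells (Homo sapiens) for antiproliferative activity, read by CCK-8 assay, with a stated time of 6 days (a higher number here means a weaker inhibitor, a lower number a stronger inhibitor), the shared core has so far given no readable number. Compound 1 `CCN(c1ccc(C#N)c(Cl)c1)c1cc(-c2ccco2)ccc1C` gives > 30000 nM as a limit and not a number. Compound 2 `CCN(c1ccc(C#N)c(Cl)c1)c1cc(-c2cncnc2)ccc1C` gives > 30000 nM as a limit as well. Compound 3 `CCN(c1ccc(C#N)c(Cl)c1)c1cc(-c2ccc(F)nc2)ccc1C` likewise gives > 30000 nM as a limit, so it stands with the other two and not on a measured number. Taken together, the series shows the limit of > 30000 nM in this assay, at which 3 of the 3 values shown sit, and nothing more.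

The next change, to compound 4 `CCN(c1ccc(C#N)c(Cl)c1)c1cc(-n2ccnc2)ccc1C`, is 1H-imidazol-1-yl in place of 6-fluoropyridin-3-yl on an aromatic carbon and puts 1H-imidazol-1-yl in place of 6-fluoropyridin-3-yl on an aromatic carbon.

Three measured steps exchange a group at this same place: a step that the two limits leave unreadable from compound 1 to compound 2 and a step that the two limits leave unreadable from compound 1 to compound 3 and also a step that the two limits leave unreadable from compound 2 to compound 3 in the series. None of them has a size, so they offer no measure of how far such an exchange can move the result. They show only that furan-2-yl, pyrimidin-5-yl and 6-fluoropyridin-3-yl all left the result at the limit in this assay as measured. No readable step is therefore expected, and any number that did appear could only point toward a stronger inhibitor. The step expected is a number no higher from compound 3 to compound 4 (the limit leaves the size open) on this reading. Compound 4 is estimated at 30000 nM within a range from 10000 nM to 60000 nM and is expected most likely to return as a limit again.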

Compound 4, half-maximal inhibitory concentration: > 30000 nM
Compound 4 was reported as a limit; the forecaster's own chance of this, stated with the estimate: 75%; the middle value lies on the limit itself.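

In this assay compound 4 gives > 30000 nM as a limit and not a number. The steps to compound 4 from compound 1, compound 2 and compound 3 therefore cannot be read. The compounds shown leave open whether any group at this place on the shared core can give a readable number.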